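The source may report more compounds than this note shows. Statements on the series, on what has been measured and on what is new or still open speak of the compounds shown alone.

In a functional assay on K562 cells (Homo sapiens) for cytotoxicity, read by MTT assay (a higher number here means a weaker inhibitor, a lower number a stronger inhibitor), compound 1 `COc1ccc(/C=C/C(=O)c2ccc(OC)c3c2OC(C)(C)C=C3)cc1OCC=C(C)C` gives > 10000 nM, which is a limit of the assay and not a number. Among the compounds with values here, compound 2 `C=CC(=O)Oc1cc(/C=C/C(=O)c2ccc(OC)c3c2OC(C)(C)C=C3)ccc1OC` gives 300 nM, the only actual number so far. Within the data shown here, the one measured step, an at least 33-fold lower number from compound 1 to compound 2 (1.52 log units; beyond the scatter), is large and brought in the vinylcarbonyl group on an oxygen on an aromatic ring. Compound 3 `COc1cccc(C(=O)Oc2cc(/C=C/C(=O)c3ccc(OC)c4c3OC(C)(C)C=C4)ccc2OC)c1` keeps that carbonyl but carries 3-methoxyphenyl in place of vinyl on a carbonyl carbon. Among the measured compounds shown here, the step of an at least 33-fold lower number from compound 1 to compound 2 (1.52 log units; beyond the scatter) is the only guide here, and it did not test the vinyl alone. Part of that large drop may therefore be lost, so a move toward a higher number in this assay, smaller than that measured step, is expected. The expected change is a 6.7-fold higher number from compound 2 to compound 3 (0.82 log units; beyond the scatter). For compound 3 the estimated value is 2000 nM, with an expected range from 400 nM to 10000 nM.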

Compound 3, half-maximal inhibitory concentration: 790 nM
Compound 3: middle estimate off by 2.5-fold (0.40 log units), on the high side, and the stated range covers the measured number.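

Swapping vinyl for the larger 3-methoxyphenyl on the same carbonyl carbon gives a 2.6-fold higher number from compound 2 to compound 3 (0.42 log units; beyond the scatter), so vinyl is not needed for a measured effect in this assay, although this change does cost some potency. The carbonyl-bearing group on that oxygen still compares well with 3-methylbut-2-en-1-yl, with an at least 12-fold lower number from compound 1 to compound 3 (1.10 log units; beyond the scatter), so among these three compounds both carbonyl-bearing groups go with lower numbers. For compound 1 this comparison starts from a limit and not a number: the limit of > 10000 nM in this assay, at which 1 of the 3 values shown sits.

The compounds shown leave open whether the carbonyl itself matters, since a plain ethyl or benzyl group on that oxygen is not among them. They also leave open whether the methoxy group of 3-methoxyphenyl contributes, which a plain phenyl group or a small amine on the carbonyl carbon could help to settle.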